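From piperidin-1-yl to cyclooctylamino in compound 3

A few compounds are considered here, and "the series" means these few. Any claim that something is new, unique, unknown or untested is made for them only; others in the source may bear on it.

For the measured compounds named here, in a functional assay on MIA PaCa-2 cells (Homo sapiens) for cytotoxicity, read by fluorescence, with a stated time of 48 h (on this read-out lower numbers stand for an effect already at smaller amounts and higher numbers for an effect only at larger amounts of compound), compound 2 `CC(C)=CCC/C(C)=C/CC/C(C)=C/CSC[C@H](NC(=O)CCCCCN1CCCC1)C(=O)N1CCCCC1` gives 12400 nM, the higher of the two numbers so far, while compound 1 `CC(C)=CCC/C(C)=C/CC/C(C)=C/CSC[C@H](NC(=O)CCCCCN1CCN(C)CC1)C(=O)NC1CCCCCCC1` gives 2500 nM, a gap beyond the scatter. Compound 3 `CC(C)=CCC/C(C)=C/CC/C(C)=C/CSC[C@H](NC(=O)CCCCCN1CCCC1)C(=O)NC1CCCCCCC1` has cyclooctylamino in place of piperidin-1-yl on a carbonyl carbon. Compound 1 also bears cyclooctylamino on a carbonyl carbon, and its value of 2500 nM is the ground for expecting a lower number. The step expected in this assay is a 3.5-fold lower number from compound 2 to compound 3 (0.55 log units; beyond the scatter), which would lie beyond the scatter. For compound 3 the estimated value is 3500 nM, with an expected range from 1300 nM to 9000 nM.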

Compound 3, half-maximal effective concentration: 1900 nM
Estimate against measurement, compound 3: 1.8-fold (0.27 log units) above; the range from low to high includes it.
By their numbers in this assay, from the lowest: compounds 3 and 1 (each within the scatter of the next); then compound 2.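

In this assay, for the compounds shown here, cyclooctylamino in place of piperidin-1-yl on a carbonyl carbon gives a 6.5-fold lower number from compound 2 to compound 3 (0.81 log units; beyond the scatter), the first reading of this position with only one place changed. Pyrrolidin-1-yl in place of 4-methylpiperazin-1-yl on a saturated chain carbon, five bonds along the chain from a carbonyl carbon, gives a 1.3-fold lower number from compound 1 to compound 3 (0.12 log units; within the scatter), so this exchange shows no effect beyond the scatter when cyclooctylamino is present. Nothing measured here explains either step.

The compounds shown leave open whether the ring size or the amide hydrogen goes with the first step. A cyclohexylamino group on that carbonyl carbon would help separate the two.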